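This account rests on a few compounds, and the source may have more. Where it says the series, first, only, none or still open, it means among the compounds named here.

Measured in a functional assay on MCF7 cells (Homo sapiens) for cytotoxicity, read by CellTiter-Glo, with a stated time of 5 days; a higher number here means a weaker inhibitor, a lower number a stronger inhibitor:
Compound 1 `CC/C(=C(/c1ccc(/C=C/C(=O)O)cc1)c1cccc2[nH]ncc12)c1ccccc1`: 21 nM
Compound 2 `CC/C(=C(\c1ccc2[nH]ncc2c1)c1ccc(/C=C/C(=O)O)cc1C)c1ccccc1`: 36 nM
Compound 3 `CC/C(=C(/c1ccc(/C=C/C(=O)O)cc1)c1ccc2[nH]ncc2c1)c1ccccc1Cl`: 2 nM

Compound 3 holds the lowest of the three numbers, and compound 1 and compound 2 both sit above it by more than the scatter. Compound 4 `CC/C(=C(/c1ccc(/C=C/C(=O)O)cc1)c1ccc2[nH]ncc2c1)c1ccccc1S(C)(=O)=O` carries methylsulfonyl in place of chloro on an aromatic carbon, ortho to a large group, relative to compound 3: methylsulfonyl in place of chloro on an aromatic carbon. Among the measured compounds shown here, no two measured compounds differ in one place, and no measured step covers this change. For the measured compounds named here, since compound 3 stands at 2 nM, the lowest number so far, a higher number is expected in this assay, with a step probably beyond the scatter. The estimated move is a 6.0-fold higher number from compound 3 to compound 4 (0.78 log units; beyond the scatter). For compound 4 the expected value is 12 nM, with an estimated range of 3 nM to 50 nM.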

Compound 4, half-maximal inhibitory concentration: 70 nM
For compound 4 the middle estimate is 5.8-fold (0.77 log units) below the measured one, outside the stated range (above it).
By their numbers in this assay, from the lowest: compound 3; then compounds 1, 2 and 4 (each within the scatter of the next, the first and the last beyond it).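

In this assay, among the compounds shown here, methylsulfonyl in place of chloro on an aromatic carbon, ortho to a large group, gives the first single-place comparison: a 35-fold higher number from compound 3 to compound 4 (1.54 log units; beyond the scatter). The number at this position therefore depends strongly on the group it carries, and the low value of compound 3 does not survive this exchange. No available data bear on the reason for the step.

Only chloro and methylsulfonyl can be compared directly at this position. On these data alone, how fluoro, methyl or methoxy would read there stays open.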